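Third chloro step in the aryl urea series

The compounds below may be only part of what the source reports. "The series", "measured", "known", "first", "only" and "open" are said of these compounds alone.

Compound 3 `C[C@H](NC(=O)Nc1cccc(Cl)c1)c1ccccc1` is measured in an ADME assay on the whole organism with Oryza sativa as the target, tested at 0.1 uM (a higher number here means a weaker effect of the compound at the concentration tested, a lower number a stronger effect), and gives 103%. Compound 2 `CCc1cccc(NC(=O)N[C@@H](C)c2ccccc2)c1` gives 100%, and compound 1 `Cc1cccc(NC(=O)N[C@@H](C)c2ccccc2)c1` gives 99%. The gaps are a number 4 percentage points higher from compound 1 to compound 3 (within the scatter) and a number 3 percentage points higher from compound 2 to compound 3 (within the scatter), so compound 3 is not told apart from the other two on these numbers. Compound 4 `C[C@H](NC(=O)Nc1ccc(Cl)c(Cl)c1)c1ccccc1` differs from compound 3 by chloro in place of hydrogen on an aromatic carbon, placed on an aromatic carbon of a six-membered aromatic ring of carbon only, ortho to a chloro group and para to a large group. Among the measured compounds shown here, the steps that bear on it are those in which chloro entered the same ring: a number 4 percentage points higher from compound 1 to compound 3 (within the scatter) and a number 3 percentage points higher from compound 2 to compound 3 (within the scatter), both within the scatter. The remaining step, a number 1 percentage points higher from compound 1 to compound 2 (within the scatter), is on the saturated chain and is also within the scatter. For the measured compounds named here, no measured step moves this assay beyond its scatter, so no step beyond the scatter is expected in this assay from a further chloro either; the expected step is a number 1 percentage points lower from compound 3 to compound 4 (within the scatter). Compound 4 is estimated at 102%, in the range 94% to 110%.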

Compound 4, a percentage reported as activity, at one concentration (the size of the read-out at that concentration, not a potency): 98%
The estimate for compound 4 lay 4 percentage points above the measured number; the measured number falls inside the stated range.
By their numbers in this assay, from the lowest: compounds 4, 1, 2 and 3 (each within the scatter of the next).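

In this assay, chloro in place of hydrogen on an aromatic carbon, ortho to a chloro group and para to a large group, gives a number 5 percentage points lower from compound 3 to compound 4 (within the scatter). Among the compounds shown here, this is the first step at this position, and the first to put a second chloro on the ring; the position accepts that chloro with no step beyond the scatter, as with every earlier step. No measurement bears on why the number stays within the scatter here.

Going by these compounds, only hydrogen and chloro are compared at this position, so it remains open whether a methoxy, an amine or a carboxylic acid there would give a step beyond the scatter. With every step so far within the scatter, the compounds shown do not reveal which change, if any, moves this read-out.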